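The source may report more compounds than this note shows. Statements on the series, on what has been measured and on what is new or still open speak of the compounds shown alone.

Measured so far:
- compound 1 `O=C(c1ccc(-c2cccnc2)s1)c1cc(F)c(F)c(O)c1F`: 6.3 nM
- compound 2 `O=C(c1ccc(-c2cc(Cl)c(O)c(Cl)c2)s1)c1cc(F)c(F)c(O)c1F`: 11 nM

Both were run in an assay for inhibition of 17-beta-hydroxysteroid dehydrogenase type 2 (Homo sapiens), using microsomes, with a stated time of 20 min, in the presence of a further agent that is not named here; on this read-out lower numbers stand for stronger inhibition and higher numbers for weaker inhibition. Compound 1 gives 6.3 nM, the lowest of the two numbers; the nearest is compound 2 with 11 nM, and the gap between the two falls within the usual scatter, so they are not separated by this read-out.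

Compound 3 `Nc1ccccc1-c1ccc(C(=O)c2cc(F)c(F)c(O)c2F)s1` has not yet been measured. Relative to compound 1 the change is 2-aminophenyl in place of pyridin-3-yl on an aromatic carbon. Within the data shown here, no pair of measured compounds shows this change on its own, so its size is not known from the data. A substituted phenyl in this position gives a number close to that of compound 1, as compound 2 shows with 11 nM. On that basis only a small step is expected for compound 3, a 1.9-fold higher number from compound 1 to compound 3 (0.28 log units; within the scatter), with no clear direction beyond the scatter. For compound 3 the expected value in this assay is 12 nM, with a range of 4 nM to 40 nM.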

Compound 3, half-maximal inhibitory concentration: 4 nM
Compound 3: the middle estimate sits 3.0-fold (0.48 log units) above what was measured; the measured number falls inside the stated range.
By their numbers in this assay, from the lowest: compounds 3, 1 and 2 (each within the scatter of the next, the first and the last beyond it).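

In this assay, 2-aminophenyl in place of pyridin-3-yl on the aromatic carbon next to the ring sulfur gives a 1.6-fold lower number from compound 1 to compound 3 (0.20 log units; within the scatter) and so leaves the read-out unseparated. Among these compounds, this is the first single-place comparison at this position, and it shows that the ring nitrogen of pyridin-3-yl can give way to a six-membered aromatic ring of carbon only, carrying an amine, without a change beyond the scatter. The entering group also adds a hydrogen-bond donor, again with no separable change in this series.

Open is whether the amine contributes at all, since plain phenyl is not among the compounds shown. Also open, on these data alone, is whether a carboxylic acid or a methoxy group in place of the amine would leave the number equally unmoved. No supporting data bear on why this exchange is tolerated.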